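Cytotoxicity Stays at the Assay Limit Across Aryl Variants

This account rests on a few compounds, and the source may have more. Where it says the series, first, only, none or still open, it means among the compounds named here.

Measured compounds in an ADME assay on HEK293 cells (Homo sapiens) for cytotoxicity, read by CellTiter-Glo and resazurin assay, with a stated time of 72 h; on this read-out lower numbers stand for an effect already at smaller amounts and higher numbers for an effect only at larger amounts of compound:
Compound 1, `Cc1nnc(-c2cccc(-c3ccc(C(=O)N(Cc4cccc(OCCCCCC(=O)O)c4)C(C)C)cc3)c2)o1`: > 26000 nM, a limit of the assay.
Compound 2, `CC(C)N(Cc1cccc(OCCCCCC(=O)O)c1)C(=O)c1ccc(-c2ccc3[nH]ccc3c2)cc1`: > 26000 nM, a limit of the assay.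
Compound 3, `CCOc1cccc(-c2ccc(C(=O)N(Cc3cccc(OCCCCCC(=O)O)c3)C(C)C)cc2)c1`: > 20800 nM, a limit of the assay.

Compound 3 stands at a limit, as do the other two; the three values sit at the limit of > 20800 nM in this assay, at which 1 of the 3 values shown sits, and (the limit of > 26000 nM in this assay, at which 2 of the 3 values shown sit). Consequently the steps a step that the two limits leave unreadable from compound 1 to compound 2, a step that the two limits leave unreadable from compound 1 to compound 3 and a step that the two limits leave unreadable from compound 2 to compound 3 cannot be read. Compound 4, `CC(C)N(Cc1cccc(OCCCCCC(=O)O)c1)C(=O)c1ccc(-c2c[nH]c3ccccc23)cc1`, differs from compound 3 by 1H-indol-3-yl in place of 3-ethoxyphenyl on an aromatic carbon. For the measured compounds named here, no measured step bears readably on this change, and compound 2, which carries an indolyl group, also sits at a limit. Compound 4 is therefore expected to remain at the limit in this assay, with an estimate of 30000 nM ranging from 15000 nM to 60000 nM, and the expected step that the limit leaves unreadable from compound 3 to compound 4 is no more than scatter.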

Compound 4, half-maximal effective concentration: > 26000 nM
Compound 4 was reported as a limit; the forecaster's own chance of this, stated with the estimate: 85%; the middle value lies beyond the limit too.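

The steps to compound 4 from compound 1, compound 2 and compound 3 cannot be read in this assay, as all four values are limits. The compounds shown leave open whether these aryl groups differ at all in cytotoxicity, and at what concentration any of them would reach a half-maximal effect.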